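The compounds below may be only part of what the source reports. "The series", "measured", "known", "first", "only" and "open" are said of these compounds alone.

Working notes on the series. Compound 2 `CC(C)/N=C(\NC1=NC(=O)CN1C(C)C)Nc1ccc(Cl)c(Cl)c1` gives 0.283 h in an in vivo ADME assay on the whole organism for metabolic stability, with Mus musculus as the target, read by LC-MS, at a dose of 320 mg/kg by the oral route (a higher number here means that the compound lasts longer, a lower number that the compound disappears faster), the second highest of the three numbers. Compound 1 `CC(C)N/C(=N\C(=O)C(C)(C)C)NC1=NC(=O)CN1c1ccc(Cl)c(Cl)c1` gives 0.225 h in this assay, within the scatter of compound 2. Compound 3 `CC(C)/N=C(\NC1=NC(=O)CN1C)Nc1ccc(Cl)c(Cl)c1` gives 0.83 h in this assay, and the one step shown in the set, a 2.9-fold higher number from compound 2 to compound 3 (0.47 log units; beyond the scatter), follows a methyl in place of isopropyl on an amine nitrogen in a ring.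

Compound 4 `CCC(CC)C(=O)/N=C(\NC1=NC(=O)CN1C(C)C)Nc1ccc(Cl)c(Cl)c1` differs from compound 2 by (pentan-3-yl)carbonyl in place of isopropyl on a double-bonded nitrogen. Going by the values given here, no measured step touches a double-bonded nitrogen, so the change between compound 2 and compound 4 has no direct precedent here. Among the compounds with values here, the only indication is that compound 1, the one compound carrying a carbonyl, and compound 2 show values within the scatter of each other. On that basis the step is expected to be a 1.0-fold lower number from compound 2 to compound 4 (0.00 log units; within the scatter), that is, none beyond the scatter. Compound 4 is estimated at 0.28 h in this assay, with a range of 0.12 h to 0.65 h.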

Compound 4, half-life: 0.0833 h
Beside the measured number, compound 4's estimate is 3.4-fold (0.53 log units) above it; the measured number lies below the stated range.
By their numbers in this assay, from the lowest: compound 4; then compounds 1 and 2 (each within the scatter of the next); then compound 3.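

Going by these compounds alone, on a double-bonded nitrogen, a position no earlier step touched, (pentan-3-yl)carbonyl in place of isopropyl gives a 3.4-fold lower number from compound 2 to compound 4 (0.53 log units; beyond the scatter) in this assay and so shows that this position is not silent for the half-life. Within the data shown here, the step runs in the opposite direction to the only other measured step, a 2.9-fold higher number from compound 2 to compound 3 (0.47 log units; beyond the scatter) on an amine nitrogen in a ring. Nothing measured in the series bears on what lies behind the fall, so it stands as an observation only.

Still open, going by these compounds, is whether acetyl or a plain pentan-3-yl without the carbonyl on the double-bonded nitrogen would give the same fall in this assay and so separate the carbonyl from the chain. Also open, on these data alone, is whether the methyl on the amine nitrogen in a ring, with compound 3 at 0.83 h in this assay, would keep its effect alongside (pentan-3-yl)carbonyl.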